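Working notes: expected cytotoxicity of compound 3

This account rests on a few compounds, and the source may have more. Where it says the series, first, only, none or still open, it means among the compounds named here.

Measured so far:
compound 1 `CC(=O)C[C@H]1O[C@@H](On2cc(CN3C(=O)/C(=N\Nc4ccc(F)cc4)c4ccccc43)nn2)[C@H](OC(C)=O)[C@@H](OC(C)=O)[C@H]1OC(C)=O` — 78600 nM
compound 2 `CC1(C)O[C@H]2O[C@H](Cn3cc(CN4C(=O)/C(=N\Nc5ccc(Br)cc5)c5ccccc54)nn3)[C@H](O)[C@H]2O1` — 72900 nM

In an ADME assay on Vero cells (Chlorocebus sabaeus) for cytotoxicity, read by fluorescence and resazurin assay, with a stated time of 3 days (a lower number here means that less compound is tolerated, a higher number that more compound is tolerated), compound 1 gives 78600 nM and compound 2 gives 72900 nM. The two numbers sit within the usual scatter of each other, so compound 2 stands level with compound 1 on what has been measured. Compound 3 `CC1(C)O[C@H]2O[C@H](Cn3cc(CN4C(=O)/C(=N\Nc5cccc(Cl)c5)c5ccccc54)nn3)[C@H](O)[C@H]2O1` differs from compound 2 in one place: 3-chlorophenyl in place of 4-bromophenyl on an amine nitrogen. Among the compounds with values here, no step between measured compounds is available to calibrate this change, so no movement beyond the scatter is expected in this assay in either direction. Compound 3 is estimated at 70000 nM, with a range of 35000 nM to 140000 nM. The expected step of a 1.0-fold lower number from compound 2 to compound 3 (0.02 log units; within the scatter) is essentially none.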

Compound 3, half-maximal cytotoxic concentration: 70000 nM
Compound 3: middle estimate and measured number agree at the digits printed, and the stated range covers the measured number.
By their numbers in this assay, from the lowest: compounds 3, 2 and 1 (each within the scatter of the next).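

In this assay, within the data shown here, the exchange of 3-chlorophenyl in place of 4-bromophenyl on an amine nitrogen reads a 1.0-fold lower number from compound 2 to compound 3 (0.02 log units; within the scatter) and gives the series its only one-place comparison. At this position, the halogen and its ring position can therefore both differ while the numbers stay within the scatter, although this single step cannot separate the two differences. Nothing available explains this result. Open, as far as these compounds go, is whether an unsubstituted phenyl, or a phenyl carrying an amine or a carboxylic acid, would stay within the scatter here. Also open, from the compounds shown here alone, is whether the same exchange would read alike on the core of compound 1.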